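Removing a ring methyl in a thiol neprilysin inhibitor series

The source may hold more compounds than are shown below. What is called first, only, known or untested is meant among the compounds shown, and "the series" means these compounds.

Measured so far:
- compound 1, `CN1C(=O)CC[C@H](NC(=O)[C@@H](S)Cc2ccccc2)C(=O)N1CC(=O)O`, 55 nM
- compound 2, `CN1CCC[C@H](NC(=O)[C@@H](S)Cc2ccccc2)C(=O)N1CC(=O)O`, 484 nM

Both compounds were tested in an assay on isolated protein for inhibition of Neprilysin (Homo sapiens); on this read-out higher numbers stand for weaker inhibition and lower numbers for stronger inhibition. Compound 1 gives 55 nM, and compound 2 gives 484 nM, which is the higher of the two numbers and stands clearly apart from compound 1. Among the measured compounds shown here, nothing else has been measured, so no step between compounds of this kind has been observed yet.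

Compound 3 is `O=C(O)CN1NCCC[C@H](NC(=O)[C@@H](S)Cc2ccccc2)C1=O`. It differs from compound 2 in one place: hydrogen in place of methyl on an amine nitrogen in a ring. In plain words, a hydrogen takes the place of a methyl on an amine nitrogen in a ring.

For the measured compounds named here, there is no measured pair here that would show what such a change does in this assay. The change is small and touches only one heavy atom, so a step of modest size in either direction, or none beyond the scatter, seems the most reasonable expectation. The estimated step from compound 2 to compound 3 is a 1.4-fold lower number from compound 2 to compound 3 (0.14 log units; within the scatter). Compound 3 is therefore expected to give about 350 nM in this assay, within a range from 120 nM to 1000 nM.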

Compound 3, half-maximal inhibitory concentration: 486 nM
The estimate for compound 3 lay 1.4-fold (0.14 log units) below the measured number; low and high end bracket the measured number.
By their numbers in this assay, from the lowest: compound 1; then compounds 2 and 3 (each within the scatter of the next).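

In this assay, replacing the methyl with hydrogen on the amine nitrogen in the ring gives a 1.0-fold higher number from compound 2 to compound 3 (0.00 log units; within the scatter). Among the compounds shown here, this is the first measured pair for this change, and it shows that, on the core shared by these two compounds, the methyl on this nitrogen can be exchanged for hydrogen without a difference that rises above the usual variation between repeated measurements. Nothing available explains why the two compounds read alike in this assay.

This single pair cannot show whether the same exchange would be equally silent on the core of compound 1, which carries a ring carbonyl and gives 55 nM. It also leaves open how larger groups on this nitrogen, such as an ethyl, a benzyl or an acetyl group, would read, so the result describes only the difference between a methyl and a hydrogen, not what this position accepts more generally.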